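The source may hold more compounds than are shown below. What is called first, only, known or untested is meant among the compounds shown, and "the series" means these compounds.

Measured in a physicochemical assay for solubility, read by nephelometry, measured as kinetic solubility, at pH 2; on this read-out lower numbers stand for lower solubility and higher numbers for higher solubility:
Compound 1 `O=C(Nc1ccnc(C(F)(F)F)c1)Nc1ccnc(C(F)(F)F)c1`: 12.5 ug/mL
Compound 2 `O=C(Nc1ccc(F)c(C(F)(F)F)c1)Nc1cnccn1`: 1.6 ug/mL

In this assay compound 2 holds the lower of the two numbers at 1.6 ug/mL. Compound 1 stands at 12.5 ug/mL, and this gap lies beyond the usual scatter. The two compounds differ in more than one place, so the gap cannot be tied to any single change.

Compound 3 `O=C(Nc1ccc(F)c(C(F)(F)F)c1)Nc1ccccn1` has not yet been measured. It carries pyridin-2-yl in place of pyrazin-2-yl on an amide-type nitrogen. For the measured compounds named here, no measured pair shows this change, so any expectation is loose. Going by the values given here, with compound 2 at 1.6 ug/mL, the lower number so far, a modest rise is expected, close to the edge of the scatter. The expected step is a 2.5-fold higher number from compound 2 to compound 3 (0.40 log units; beyond the scatter). For compound 3 the estimated value is 4 ug/mL, with an expected range of 1.6 ug/mL to 12.5 ug/mL.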

Compound 3, solubility: 1.6 ug/mL
Estimate against measurement, compound 3: 2.5-fold (0.40 log units) above, within the range that was stated.
By their numbers in this assay, from the lowest: compounds 2 and 3 (each within the scatter of the next); then compound 1.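

For the compounds shown here, compound 2 and compound 3 form the first pair that differs in one place, so a single change can now be read directly. In this assay, pyridin-2-yl in place of pyrazin-2-yl on an amide-type nitrogen gives no change at the digits printed from compound 2 to compound 3 (within the scatter). At this position, then, going from a ring with 2 hetero atoms and 2 hydrogen-bond acceptors to one with 1 hetero atom and 1 hydrogen-bond acceptor leaves the read-out unmoved, and no evidence is at hand that bears on this result.

The compounds shown leave open whether this holds for a group of another kind on the same nitrogen, such as a piperidine or a phenyl ring carrying a carboxylic acid. They also leave open whether the same change would read alike with a different group on the other side of the carbonyl.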